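The source may report more compounds than this note shows. Statements on the series, on what has been measured and on what is new or still open speak of the compounds shown alone.

Measured compounds:
compound 1 `Cc1ccc(S(=O)(=O)N2C(C)C2CO[C@@H]2O[C@@H]3CO[C@H](c4ccccc4)O[C@@H]3[C@H](OCc3ccccc3)[C@H]2OCc2ccccc2)cc1`: 804000 nM
compound 2 `Cc1ccc(S(=O)(=O)N2C(CO[C@@H]3O[C@@H]4CO[C@H](c5ccccc5)O[C@@H]4[C@H](OCc4ccccc4)[C@H]3OCc3ccccc3)C2(C)C)cc1`: > 1000000 nM
compound 3 `Cc1ccc(S(=O)(=O)N2C(C)C2CO[C@@H]2O[C@@H]3CO[C@H](c4ccccc4)O[C@@H]3[C@H](O)[C@H]2O)cc1`: 351000 nM

In a functional assay on A549 cells (Homo sapiens) for cytotoxicity, read by MTT assay, with a stated time of 48 h (on this read-out higher numbers stand for weaker inhibition and lower numbers for stronger inhibition), compound 3 gives 351000 nM, the lowest of the two numbers shown, and the gap to compound 1 at 804000 nM lies beyond the usual scatter. The difference between the core of compound 3 and the core of compound 1 is not broken down here. Compound 2 sits at the limit of this assay, (the limit of > 1000000 nM in this assay, at which 1 of the 3 values shown sits), so its value is a limit and not a number. The change methyl in place of hydrogen on a saturated ring carbon therefore gives an at least 1.2-fold higher number from compound 1 to compound 2 (0.09 log units; that floor lies within the scatter), a floor that lies within the scatter.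

Compound 4 `Cc1ccc(S(=O)(=O)N2C(CO[C@@H]3O[C@@H]4CO[C@H](c5ccccc5)O[C@@H]4[C@H](O)[C@H]3O)C2(C)C)cc1` is not yet measured. It differs from compound 3 by methyl in place of hydrogen on a saturated ring carbon, the same change as between compound 1 and compound 2, made on the core of compound 3. Compound 4 is expected to show a 1.4-fold higher number from compound 3 to compound 4 (0.15 log units; within the scatter) in this assay, an expectation that rests on the step of an at least 1.2-fold higher number from compound 1 to compound 2 (0.09 log units; that floor lies within the scatter) from the same change. Compound 4 is therefore estimated at 500000 nM, between 250000 nM and 1000000 nM.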

Compound 4, half-maximal inhibitory concentration: 389000 nM
Compound 4: middle estimate off by 1.3-fold (0.11 log units), on the high side; measured number inside the range.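

In this assay, methyl in place of hydrogen on a saturated ring carbon gives a 1.1-fold higher number from compound 3 to compound 4 (0.04 log units; within the scatter), so on the core of compound 3 the change produces no difference that can be told from the scatter. Set beside the step on the core of compound 1, the result fits a change that carries over with little effect, but it does not show that the two steps are the same: the same change on two cores in this assay, an at least 1.2-fold higher number (0.09 log units; that floor lies within the scatter) from compound 1 to compound 2 and a 1.1-fold higher number (0.04 log units; within the scatter) from compound 3 to compound 4; the limit leaves it open whether they differ Compound 2 stands at a limit and not at a number, so the true size of the earlier step stays unknown and this pair of cores can neither confirm nor refute a transfer of the change: the limit of > 1000000 nM in this assay, at which 1 of the 4 values shown sits.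

The compounds shown leave open whether an ethyl group, a longer chain or an amine on the same ring carbon would shift the number beyond the scatter. From the compounds shown here alone, whether an acetyl group in place of the (4-methylphenyl)sulfonyl group would alter this picture also stays open.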